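From Methyl to Phenyl on a Saturated Ring Carbon

A few compounds are considered here, and "the series" means these few. Any claim that something is new, unique, unknown or untested is made for them only; others in the source may bear on it.

Compound 1 `COc1cc(N)c(Cl)cc1C(=O)NC1CCN2C[C@H](c3ccccc3)CC2C1` was examined in a functional assay on the whole organism for antagonist activity, with Mus musculus as the target; a higher number here means that more compound is needed for the effect, a lower number that less compound is needed. For compound 1 the result is recorded only as > 3 mg/kg, which is a limit of the assay and not a number. Compound 2 `COc1cc(N)c(Cl)cc1C(=O)NC1CCN2CC(C)(c3ccccc3)CC2C1` gives 0.078 mg/kg in this assay, and this is the only number shown. The remaining value, that of compound 1, is the limit of > 3 mg/kg in this assay, at which 1 of the 2 values shown sits.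

Compound 3 `COc1cc(N)c(Cl)cc1C(=O)NC1CCN2CC(c3ccccc3)(c3ccccc3)CC2C1` has not yet been measured. It differs from compound 2 by phenyl in place of methyl on a saturated ring carbon. For the measured compounds named here, no step between two measured compounds is available to guide the expectation. In this assay the expected step is a 2.6-fold higher number from compound 2 to compound 3 (0.41 log units; beyond the scatter), a modest shift toward a higher dose that may not exceed the usual scatter. Compound 3 is accordingly expected to give about 0.2 mg/kg in this assay, with a range from 0.03 mg/kg to 1.5 mg/kg.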

Compound 3, dose for half-maximal effect: > 1 mg/kg
Compound 3 ended at the assay's limit (the forecaster's own chance of this, stated with the estimate: 15%); middle value at least 5.0-fold (0.69 log units) from the limit.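

Phenyl in place of methyl on this saturated ring carbon gives an at least 12-fold higher number from compound 2 to compound 3 (1.10 log units; beyond the scatter), the first step that can be read at this position, and it shows that the dose needed depends strongly on the group carried there. Going by these compounds, compound 3 is recorded only as a limit of the assay, > 1 mg/kg, so the step sets a lower bound and its true size remains unknown. In this assay, only compound 2, with methyl on this carbon, gives a number, while compound 1 and compound 3 both end at limits.

On these data alone, whether a group such as ethyl or hydroxyl on the same carbon would keep the low dose of compound 2 remains open. The compounds shown also do not tell why phenyl in place of methyl has this effect.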